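A few compounds are considered here, and "the series" means these few. Any claim that something is new, unique, unknown or untested is made for them only; others in the source may bear on it.

Working notes on the series

In a functional assay on BJAB cells (Homo sapiens) for antiproliferative activity, with a stated time of 4 days (a lower number here means that less compound is needed, a higher number that more compound is needed for the effect), compound 2 `COc1cncc(-c2c(C)nn(-c3nc(-c4ccc(Cl)c(Cl)c4)c(SC(C)C)s3)c2C(=O)O)c1` gives 21000 nM. Of the two numbers reported in this assay it carries the lower one; compound 3 `CCSc1sc(-n2nc(C)c(Cc3ccccc3[N+](=O)[O-])c2C(=O)OC)nc1-c1ccc(Cl)c(Cl)c1` gives 106000 nM in this assay, a step from compound 2 that lies beyond the scatter of the method. Compound 1 `Cc1c(-c2cc(Cl)cc(Cl)c2)c(C(=O)O)nn1-c1nc(-c2cnn(C)c2)c(SC(C)C)s1` is reported in this assay as "not active" (no number reported), with no number attached, and so cannot be placed against the other two.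

Compound 4 `Cc1nn(-c2nc(-c3ccc(Cl)c(Cl)c3)c(SC(C)C)s2)c(C(=O)O)c1-c1ccncc1` has not been measured in this assay. Its structure differs from compound 2 in one place: pyridin-4-yl in place of 5-methoxypyridin-3-yl on an aromatic carbon. Among the compounds with values here, no pair of measured compounds differs in that single place, so nothing measured tells how such a swap moves the number. Within the data shown here, the three measured compounds all sit in the weak range, and the one swap that is bracketed by numbers, from compound 2 to compound 3, changes several parts of the structure at once.

Given this, no step beyond the scatter is expected in this assay for compound 4, and the number is estimated to stay close to that of compound 2, with the step of a 1.4-fold higher number from compound 2 to compound 4 (0.15 log units; within the scatter) expected to lie within the scatter. Compound 4 is estimated at 30000 nM in this assay, with a range from 10000 nM to 90000 nM.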

Compound 4, half-maximal effective concentration: 5900 nM
The estimate for compound 4 lay 5.1-fold (0.71 log units) above the measured number, and the stated range ends above it.
By their numbers in this assay, from the lowest: compound 4; then compound 2; then compound 3.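

Within the data shown here, the swap to pyridin-4-yl on this aromatic carbon, next to the ring atom that bears a carboxy group, gives a 3.6-fold lower number from compound 2 to compound 4 (0.55 log units; beyond the scatter) in this assay and is the only step that can be read at a single place. Among these compounds, it shows that the number in this assay moves beyond the scatter when only this group changes and the rest of the structure stays the same, a point that the comparison of compound 2 with compound 3 could not make, as those two differ in several places. The step is modest, however, and nothing measured on these compounds bears on the reason for it.

The change removes the methoxy group and alters how the pyridine ring is attached in a single move, so the compounds shown do not separate these two differences, which a plain pyridin-3-yl group would begin to do. Also open, going by these compounds, is how the number responds at this carbon to a group of another kind, such as an aminomethyl group or a morpholine ring, and whether the step holds on other versions of the shared core.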